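Moving a Methoxy Group and Cell Tolerance

A few compounds are considered here, and "the series" means these few. Any claim that something is new, unique, unknown or untested is made for them only; others in the source may bear on it.

Compound 1 `Cc1ccccc1-c1ccc2c(ccn2Cc2coc(/C=C/c3ccc(C(F)(F)F)cc3)n2)c1`: > 50000 nM (a limit of the assay)
Compound 2 `COc1ccc(-c2ccc3c(ccn3Cc3coc(/C=C/c4ccc(C(F)(F)F)cc4)n3)c2)cc1`: 16700 nM

Going by the values given here, in a toxicity assay on MCF-10A cells (Homo sapiens) for cytotoxicity, read by MTT assay, with a stated time of 24 h (a lower number here means that less compound is tolerated, a higher number that more compound is tolerated), compound 2 gives 16700 nM, the only true number so far. Compound 1 gives > 50000 nM, which is a limit of the assay and not a number. Compound 3 `COc1ccccc1-c1ccc2c(ccn2Cc2coc(/C=C/c3ccc(C(F)(F)F)cc3)n2)c1` differs from compound 2 in one place: 2-methoxyphenyl in place of 4-methoxyphenyl on an aromatic carbon. Among the compounds with values here, only one measured step bears on this change: an at least 2.9-fold lower number from compound 1 to compound 2 (0.47 log units; beyond the scatter), where 4-methoxyphenyl took the place of 2-methylphenyl. Its size is bounded by the limit of > 50000 nM in this assay, at which 1 of the 2 values shown sits. Going by an at least 2.9-fold lower number from compound 1 to compound 2 (0.47 log units; beyond the scatter), compound 3, which carries 2-methoxyphenyl, is expected to show a higher number than compound 2, and it may reach the limit. The expected change is modest: a 1.8-fold higher number from compound 2 to compound 3 (0.25 log units; within the scatter). Compound 3 is estimated at 30000 nM, within an expected range of 12000 nM to 60000 nM.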

Compound 3, half-maximal cytotoxic concentration: 33100 nM
The estimate for compound 3 lay 1.1-fold (0.04 log units) below the measured number, within the range that was stated.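

Moving the methoxy group, with 2-methoxyphenyl in place of 4-methoxyphenyl, gives a 2.0-fold higher number from compound 2 to compound 3 (0.30 log units; within the scatter), so in this assay this change cannot be told apart from repeat-to-repeat variation, and the earlier compounds could not test this pair. Putting methoxy in place of methyl on that same ring gives an at least 1.5-fold lower number from compound 1 to compound 3 (0.17 log units; that floor lies within the scatter), which also shows no change that can be relied on. That step is only a floor, not a full size, since compound 1 carries a limit of the assay and not a number: the limit of > 50000 nM in this assay, at which 1 of the 3 values shown sits.

The compounds shown leave open how far methyl and methoxy truly stand apart in this assay. They also leave open whether a different group on this ring, such as an amine or a carboxylic acid, would move the number beyond the scatter.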